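Working notes: from compound 2 to compound 4

The source may hold more compounds than are shown below. What is called first, only, known or untested is meant among the compounds shown, and "the series" means these compounds.

In a functional assay on HCT-116 cells (Homo sapiens) for cytotoxicity, read by sulforhodamine B assay, with a stated time of 24 h (on this read-out higher numbers stand for weaker inhibition and lower numbers for stronger inhibition), compound 2 `O=C1Nc2ccc(S(=O)(=O)N3CCOCC3)cc2/C1=N/c1cccc(C(F)(F)F)c1` gives 15900 nM. Compound 1 `O=C1Nc2ccc(S(=O)(=O)N3CCOCC3)cc2/C1=N/c1ccc(O)cc1`, at 27300 nM, lies within the scatter of compound 2. Compound 3 `O=C1Nc2ccc(S(=O)(=O)N3CCOCC3)cc2/C1=N/c1ccc(/N=C2\C(=O)Nc3ccc(S(=O)(=O)N4CCOCC4)cc32)cc1`, at 7480 nM, shows a lower number than compound 2, and that gap lies beyond the scatter.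

Compound 4 `O=C1Nc2ccc(S(=O)(=O)N3CCOCC3)cc2/C1=N/c1ccc(C(=O)O)cc1` carries 4-carboxyphenyl in place of 3-(trifluoromethyl)phenyl on a double-bonded nitrogen.

Within the data shown here, one measured step bears on this exchange, because the group on that same nitrogen also changes in a 1.7-fold lower number from compound 1 to compound 2 (0.23 log units; within the scatter), which stays within the scatter. Among the measured compounds shown here, compound 3 is not linked to compound 2 by a change in one place, so it offers no step here. For the measured compounds named here, only a single exchange at this nitrogen has been measured, so the evidence is thin. No step beyond the scatter is expected in this assay, only a slight rise in the number at most. The expected step is a 1.3-fold higher number from compound 2 to compound 4 (0.10 log units; within the scatter). Compound 4 is estimated at 20000 nM, with an expected range of 9000 nM to 45000 nM.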

Compound 4, half-maximal inhibitory concentration: 23600 nM
Compound 4: the middle estimate sits 1.2-fold (0.07 log units) below what was measured, and the stated range covers the measured number.
By their numbers in this assay, from the lowest: compound 3; then compounds 2, 4 and 1 (each within the scatter of the next).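

In this assay, 4-carboxyphenyl in place of 3-(trifluoromethyl)phenyl on the double-bonded nitrogen gives a 1.5-fold higher number from compound 2 to compound 4 (0.17 log units; within the scatter), so a second exchange of the whole group at this nitrogen also stays inside the scatter. The narrower exchange, carboxy in place of hydroxy on an aromatic carbon, gives a 1.2-fold lower number from compound 1 to compound 4 (0.06 log units; within the scatter), which shows that compound 1, compound 2 and compound 4 cannot be separated on this read-out across the three groups shown. No measured data on hand account for this flat result.

The compounds shown leave open whether an amine or a longer chain on the aromatic ring at this nitrogen would move the number beyond the scatter. Among these compounds, no step in one place links compound 3, at 7480 nM, to the others, so what sets its number also remains open.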